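A few compounds are considered here, and "the series" means these few. Any claim that something is new, unique, unknown or untested is made for them only; others in the source may bear on it.

Among the compounds with values here, compound 2 `CC1=C(/C=C/C(=O)/C=C/c2ccc(F)cc2)C(C)(C)CCC1` gives 25800 nM in a functional assay on PC-3 cells (Homo sapiens) for cytotoxicity, read by MTT assay, with a stated time of 72 h (a lower number here means a stronger inhibitor, a higher number a weaker inhibitor), the higher of the two numbers so far; compound 1 `CC1=C(/C=C/C(=O)/C=C/c2ccc(C(F)(F)F)cc2)C(C)(C)CCC1` gives 12000 nM. Within the data shown here, the single measured step, a 2.2-fold higher number from compound 1 to compound 2 (0.33 log units; beyond the scatter), is the only one that bears on the next change. Compound 3 `CC1=C(/C=C/C(=O)/C=C/c2ccc(-c3ccccc3)cc2)C(C)(C)CCC1` differs from compound 2 by phenyl in place of fluoro on an aromatic carbon. Since replacing trifluoromethyl by fluoro raised the number in this assay, the reverse direction, from fluoro to a bulkier phenyl, is expected to lower it modestly, a 2.3-fold lower number from compound 2 to compound 3 (0.37 log units; beyond the scatter). Compound 3 is estimated at 11000 nM, with a range from 4000 nM to 30000 nM.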

Compound 3, half-maximal inhibitory concentration: 47800 nM
Compound 3: middle estimate off by 4.3-fold (0.64 log units), on the low side; measured number outside the range, above it.
By their numbers in this assay, from the lowest: compound 1; then compounds 2 and 3 (each within the scatter of the next).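

In this assay phenyl in place of fluoro on the aromatic carbon para to a large group gives a 1.9-fold higher number from compound 2 to compound 3 (0.27 log units; within the scatter), so this change of six heavy atoms for one separates the two groups by no more than the scatter. Phenyl in place of trifluoromethyl gives a 4.0-fold higher number from compound 1 to compound 3 (0.60 log units; beyond the scatter), so among the three groups only trifluoromethyl stands apart. Nothing on hand accounts for this difference.

On these data alone, whether an amine or a carboxylic acid at this position would group with trifluoromethyl or with fluoro and phenyl remains open.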